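The source may hold more compounds than are shown below. What is called first, only, known or untested is meant among the compounds shown, and "the series" means these compounds.

The set is built on a shared core bearing a bromo or chloro group on the six-membered ring. Compound 1 `O=C(O)/C(S)=C/c1c[nH]c2cc(Br)ccc12` and compound 2 `O=C(O)/C(S)=C/c1c[nH]c2cc(Cl)ccc12` have the same arrangement of that core, whereas compound 3 `O=C(O)/C(S)=C/c1c[nH]c2cccc(Cl)c12` has the same atoms joined differently; the difference between the two cores is not broken down here. In an assay on isolated protein for inhibition of Calpain-1 catalytic subunit (Sus scrofa) (on this read-out lower numbers stand for stronger inhibition and higher numbers for weaker inhibition), compound 1 gives 90 nM, compound 2 gives 100 nM and compound 3 gives 140 nM. Compound 3 has the highest of the three numbers, but its gaps to compound 2 and to compound 1 are within the scatter, so no order among the three is claimed.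

Going by the values given here, the only single change measured so far is bromo in place of chloro on an aromatic carbon, which gave a 1.1-fold lower number from compound 2 to compound 1 (0.05 log units; within the scatter).

Compound 4 `O=C(O)/C(S)=C/c1c[nH]c2cccc(Br)c12` has not yet been measured. It differs from compound 3 by bromo in place of chloro on an aromatic carbon. This is the same kind of change as the one between compound 2 and compound 1, and it occurs twice among the compounds shown, but the place is not the same: in compound 1 the bromo sits meta to a fused ring and para to a fused ring, while in compound 4 it sits ortho to a fused ring and meta to a fused ring. The expectation rests on the earlier step of a 1.1-fold lower number from compound 2 to compound 1 (0.05 log units; within the scatter), which stayed within the scatter. On that basis compound 4 is expected to move by about a 1.1-fold lower number from compound 3 to compound 4 (0.03 log units; within the scatter). In this assay compound 4 is estimated at 130 nM, with a likely range from 60 nM to 280 nM.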

Compound 4, half-maximal inhibitory concentration: 100 nM
Estimate against measurement, compound 4: 1.3-fold (0.11 log units) above; the measured number falls inside the stated range.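

In this assay, bromo in place of chloro on the core of compound 3 gives a 1.4-fold lower number from compound 3 to compound 4 (0.15 log units; within the scatter), so the step stays small on this core as well. Set beside the earlier step, the same change gives steps that cannot be told apart on the two cores: the same change on two cores in this assay, a 1.1-fold lower number (0.05 log units; within the scatter) from compound 2 to compound 1 and a 1.4-fold lower number (0.15 log units; within the scatter) from compound 3 to compound 4, 1.3-fold (0.10 log units) apart, within the scatter of two such steps This shows that, across these two cores, the exchange of chloro for bromo carries over without any step or gap that rises above the scatter; it does not show that either halogen is better than the other, and it does not show that the two steps are truly equal. Nor does it show that the exchange would stay this small on any other core, since two small steps on closely related cores are all that can be read here.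

The compounds shown carry only bromo or chloro on the six-membered ring, so they leave open how fluoro, methyl, methoxy, a nitrile or an amine would read on the same ring. They also leave open how the series would respond if the carboxylic acid gave way to an ester or an amide, with the halogen kept in place.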